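Stripping the side chain from compound 3

The compounds below may be only part of what the source reports. "The series", "measured", "known", "first", "only" and "open" are said of these compounds alone.

In a functional assay on SH-SY5Y cells (Homo sapiens) for cytotoxicity, read by MTT assay, with a stated time of 72 h (on this read-out lower numbers stand for stronger inhibition and higher numbers for weaker inhibition), compound 1 `O=C1c2c[n+]([O-])c3ccccc3c2C(=O)c2c1c1ccccc1n2Cc1cn(CC(O)CO)nn1` gives > 1000 nM, which is a limit and not a number. Compound 3 `O=C1c2c[n+]([O-])c3ccccc3c2C(=O)c2c1c1ccccc1n2Cc1cn(C[C@@H](O)CO)nn1` gives > 500 nM, also a limit, so it stands somewhere on the weak side of that mark without an exact place. Among the compounds with values here, compound 2 `O=C1c2c[n+]([O-])c3ccccc3c2C(=O)c2c1c1ccccc1n2CCCCN1CCCCC1` gives 230 nM, the one exact number here. Compound 4 `O=C1c2c[n+]([O-])c3ccccc3c2C(=O)c2[nH]c3ccccc3c21` puts hydrogen on the aromatic nitrogen: hydrogen in place of (1-(2,3-dihydroxypropyl)-1H-1,2,3-triazol-4-yl)methyl on an aromatic nitrogen. Only swaps at that nitrogen have been measured, and these gave an at least 4.3-fold lower number from compound 1 to compound 2 (0.63 log units; beyond the scatter) and, in reverse, an at least 2.1-fold higher number from compound 2 to compound 3 (0.33 log units; beyond the scatter). Neither removes the side chain outright, so a modest move towards a lower number is expected, an at least 1.6-fold lower number from compound 3 to compound 4 (0.22 log units; that floor lies within the scatter). For compound 4 the estimated value is 300 nM, with an expected range from 80 nM to 1000 nM.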

Compound 4, half-maximal inhibitory concentration: 1380 nM
Compound 4: the middle estimate sits 4.6-fold (0.66 log units) below what was measured; the whole stated range lies below it.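

Replacing the 4-(piperidin-1-yl)butyl chain with hydrogen on the aromatic nitrogen gives a 6.0-fold higher number from compound 2 to compound 4 (0.78 log units; beyond the scatter). Within the data shown here, this is the first exact value for the core with no side chain at this position, and it shows that the chain of compound 2 goes with the lower number, so the bare core does not outdo it.

As far as these compounds go, the steps to compound 4 from compound 1 and compound 3 cannot be read, and both of those values are limits, so the effect of the triazole-bearing group stays open. Also open, from the compounds shown here alone, is whether a methyl group, or a propyl chain ending in the same piperidine, would match compound 2 on that nitrogen.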